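Cytotoxicity notes on the step to compound 3

A few compounds are considered here, and "the series" means these few. Any claim that something is new, unique, unknown or untested is made for them only; others in the source may bear on it.

Measured in an ADME assay on MDBK cells (Bos taurus) for cytotoxicity; a higher number here means that more compound is tolerated, a lower number that less compound is tolerated:
Compound 1 `Clc1ccc(Cn2ccc3nc(-c4ccccc4)nc-3c2)cc1`: > 100000 nM
Compound 2 `C(=C/c1ccccc1)\Cn1ccc2nc(-c3ccccc3)nc-2c1`: 78000 nM

The value of compound 1 is a limit, not a number: the limit of > 100000 nM in this assay, at which 1 of the 2 values shown sits. Among the measured compounds shown here, compound 2 therefore holds the only true number so far. In compound 3 `c1ccc(-c2nc3ccn(Cc4ccccn4)cc-3n2)cc1`, pyridin-2-yl stands in place of 2-phenylethenyl on a saturated chain carbon bound to an aromatic nitrogen (pyridin-2-yl in place of 2-phenylethenyl on a saturated chain carbon bound to an aromatic nitrogen). For the measured compounds named here, the only measured step at this place is an at least 1.2-fold lower number from compound 1 to compound 2 (0.10 log units; that floor lies within the scatter). Going by these compounds, no shift beyond the scatter is therefore expected in this assay, and the direction stays open. The expected step is a 1.2-fold higher number from compound 2 to compound 3 (0.06 log units; within the scatter). Compound 3 is estimated at 90000 nM, with an expected range of 40000 nM to 200000 nM.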

Compound 3, half-maximal cytotoxic concentration: > 100000 nM
Compound 3 ended at the assay's limit (the forecaster's own chance of this, stated with the estimate: 50%); middle value at least 1.1-fold (0.04 log units) from the limit.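

In this assay, pyridin-2-yl in place of 2-phenylethenyl gives an at least 1.2-fold higher number from compound 2 to compound 3 (0.10 log units; that floor lies within the scatter). Compound 3 stands at a limit and not at a number, so the step from compound 1 to compound 3 cannot be read. An aromatic ring with a hetero atom on this chain carbon thus reaches the same limit as the 4-chlorophenyl of compound 1: the limit of > 100000 nM in this assay, at which 2 of the 3 values shown sit.

Going by these compounds, how far compound 1 and compound 3 lie past that limit stays open, and no order among the three compounds can be given. On these data alone, whether an amine or a carboxylic acid at this place would give a true number also stays open.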